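The compounds below may be only part of what the source reports. "The series", "measured", "known", "first", "only" and "open" are said of these compounds alone.

Two compounds share one core and differ only in a group on an aromatic carbon. Compound 1 `CN(C)c1ncnc2c1ncn2Cc1ccc(F)cc1` carries a fluoro group there; in a functional assay on the whole organism for inhibition, with Rattus norvegicus as the target, at a dose of 25 mg/kg by the intraperitoneal route (on this read-out lower numbers stand for less inhibition and higher numbers for more inhibition at the one dose given (going by the name of the read-out)), compound 1 gives 21%. Compound 2 `CN(C)c1ncnc2c1ncn2Cc1ccc([N+](=O)[O-])cc1` carries a nitro group in that place, and in this assay compound 2 gives 0%. For the measured compounds named here, the single measured step is a number 21 percentage points lower from compound 1 to compound 2 (beyond the scatter). Compound 2 therefore stands lowest of the two numbers, with compound 1 the nearest and higher.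

Compound 3 `CC(=O)Nc1ccc(Cn2cnc3c(N(C)C)ncnc32)cc1` has not been measured. It differs from compound 2 in one place: acetamido in place of nitro on an aromatic carbon. Going by the values given here, no measured step exchanges nitro for acetamido, so the only guide is a number 21 percentage points lower from compound 1 to compound 2 (beyond the scatter), which shows that bringing nitro in lowered the number by a modest amount. Taking nitro out again is expected to bring part of that back, though acetamido is a different group from fluoro, so the expectation stays loose. For compound 3 in this assay the expected value is 10%, within a range from 0% to 30%. That corresponds to an expected step of a number 10 percentage points higher from compound 2 to compound 3 (within the scatter).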

Compound 3, a percentage reported as inhibition, in the whole organism at one dose (the size of the read-out at that dose, not a potency): 0%
Compound 3: the middle estimate sits 10 percentage points above what was measured, and the stated range covers the measured number.
By their numbers in this assay, from the lowest: compounds 2 and 3 (each within the scatter of the next); then compound 1.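

In this assay, exchanging nitro for acetamido on this aromatic carbon, para to a large group, gives no change at the digits printed from compound 2 to compound 3 (within the scatter), even though acetamido brings in a hydrogen-bond donor that nitro lacks. The comparison with fluoro gives a number 21 percentage points lower from compound 1 to compound 3 (beyond the scatter), so two quite different groups now each read beyond the scatter from the fluoro compound, and the earlier drop is no longer tied to nitro alone. The data shown contain no independent measurement that could explain why fluoro stands apart from these two groups.

For the compounds shown here, with only three groups at this position, it remains open whether the higher reading of compound 1 belongs to fluoro itself or would also appear with other small groups, such as chloro, a methyl group or plain hydrogen. From the compounds shown here alone, compound 2 and compound 3 both read 0%, so this single dose cannot separate them, and it remains unknown how an amine or a carboxylic acid at this position would read.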